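A Methyl Group on the Phenyl Ring: Expected Cytotoxicity

The source may report more compounds than this note shows. Statements on the series, on what has been measured and on what is new or still open speak of the compounds shown alone.

Measured compounds in a functional assay on SW-620 cells (Homo sapiens) for cytotoxicity, read by sulforhodamine B assay, with a stated time of 48 h; a higher number here means a weaker inhibitor, a lower number a stronger inhibitor:
compound 1, `C[C@H]1CC[C@@H]2[C@@H](OC(=O)[C@]23CC(c2ccccc2)=NO3)[C@]2(C)C(=O)C=C[C@@]12O`, gives 45400 nM.
compound 2, `C[C@H]1CC[C@@H]2[C@@H](OC(=O)[C@]23CC(c2ccc(N(C)C)cc2)=NO3)[C@]2(C)C(=O)C=C[C@@]12O`, gives 5100 nM.
compound 3, `C[C@H]1CC[C@@H]2[C@@H](OC(=O)[C@]23CC(c2ccc(O)cc2)=NO3)[C@]2(C)C(=O)C=C[C@@]12O`, gives 89000 nM.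

Compound 1 stands second highest of the three numbers: compound 3 sits within the scatter of it, while compound 2 lies well apart, as an 8.9-fold lower number from compound 1 to compound 2 (0.95 log units; beyond the scatter) shows. The unmeasured compound 4, `Cc1ccccc1C1=NO[C@]2(C1)C(=O)O[C@@H]1[C@H]2CC[C@H](C)[C@]2(O)C=CC(=O)[C@@]12C`, differs from compound 1 by methyl in place of hydrogen on an aromatic carbon, ortho to a large group. The measured steps, an 8.9-fold lower number from compound 1 to compound 2 (0.95 log units; beyond the scatter) and a 2.0-fold higher number from compound 1 to compound 3 (0.29 log units; within the scatter), concern other groups at another place on the ring, so they bear only loosely on this change. Compound 4 is therefore expected to stay near compound 1, giving an estimated 1.1-fold lower number from compound 1 to compound 4 (0.05 log units; within the scatter). Compound 4 is estimated at 40000 nM, between 15000 nM and 100000 nM.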

Compound 4, half-maximal inhibitory concentration: 5000 nM
Compound 4: middle estimate off by 8.0-fold (0.90 log units), on the high side, and the stated range ends above it.
By their numbers in this assay, from the lowest: compounds 4 and 2 (each within the scatter of the next); then compounds 1 and 3 (each within the scatter of the next).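

In this assay, within the data shown here, a single methyl on an aromatic carbon, ortho to a large group, is enough for a step beyond the scatter (a 9.1-fold lower number from compound 1 to compound 4 (0.96 log units; beyond the scatter)), which the earlier compounds, changed elsewhere on the ring, could not show. The change from phenyl to 2-methylphenyl puts compound 4 within the scatter of the dimethylamino compound (a 1.0-fold lower number from compound 2 to compound 4 (0.01 log units; within the scatter)) and well clear of the hydroxy compound (an 18-fold lower number from compound 3 to compound 4 (1.25 log units; beyond the scatter)). Nothing available explains why this methyl has such an effect. Going by these compounds, whether an ethyl, a methoxy or a chlorine at this place would give a similar step remains open.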